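The source may report more compounds than this note shows. Statements on the series, on what has been measured and on what is new or still open speak of the compounds shown alone.

Of the compounds shown here, two have been tested in a functional assay on HOS-TE85 cells (Homo sapiens) for inhibition, read by CCK-8 assay, with a stated time of 72 h (on this read-out lower numbers stand for stronger inhibition and higher numbers for weaker inhibition), so far. Compound 1 `O=C(NCCCCc1ccccc1)c1cccc(C2SCC(=O)N2c2nccs2)c1` gave only a limit, > 1000 nM in this assay. Compound 2 `COc1ccccc1N1C(=O)CSC1c1cccc(C(=O)NCCCCN2C(=O)C=CC2=O)c1` likewise gave only a limit, > 1000 nM in this assay. Compound 2 thus stands at the edge of what this assay reports, because of the limit of > 1000 nM in this assay, at which 2 of the 2 values shown sit. Compound 3 `COc1ccccc1N1C(=O)CSC1c1cccc(C(=O)NCCCCn2ccc3ccccc32)c1` differs from compound 2 in one place: a group of 9 heavy atoms (8 carbon, 1 nitrogen; one five-membered aromatic ring with 1 hetero atom, one six-membered aromatic ring of carbon only) in place of a group of 7 heavy atoms (4 carbon, 1 nitrogen, 2 oxygen; one five-membered non-aromatic ring with 1 hetero atom), on a saturated chain carbon, four bonds along the chain from an amide-type nitrogen. Within the data shown here, no measured step matches this kind of change, so there is nothing to point to for its size or direction. The expected step is a step that the limit leaves unreadable from compound 2 to compound 3, a modest gain in inhibition, though with no measured number for compound 2 the starting point itself is open. Compound 3 is therefore estimated at about 2000 nM in this assay, within a broad range from 300 nM to 20000 nM, and it may well again return only a limit.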

Compound 3, half-maximal inhibitory concentration: 286 nM
Estimate against measurement, compound 3: 7.0-fold (0.84 log units) above; the measured number lies below the stated range.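

In this assay, the place on a saturated chain carbon, four bonds along the chain from an amide-type nitrogen, proves able to change the read-out: putting 1H-indol-1-yl there in place of the non-aromatic five-membered ring group gives an at least 3.4-fold lower number from compound 2 to compound 3 (0.54 log units; beyond the scatter) in this series. Among these compounds, this is the first sign that the group at this position can bring a compound of this kind from a limit to a real number, which the earlier compounds could not show. Going by these compounds, the full size of the step stays unknown because compound 2 has only a limit and not a number: the limit of > 1000 nM in this assay, at which 2 of the 3 values shown sit.

The compounds shown leave open whether a plain amine, a carboxylic acid or a longer chain at this place would do as well as 1H-indol-1-yl. A single step also cannot tell which feature of 1H-indol-1-yl produces the change.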